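Pyridazinone thioureas and cyanoguanidines in rat stomach

A few compounds are considered here, and "the series" means these few. Any claim that something is new, unique, unknown or untested is made for them only; others in the source may bear on it.

Measured compounds:
Compound 1, `O=c1ccc(-c2ccccc2)nn1CCCCNC(=S)Nc1cccc2ccccc12`, > 100 mg/kg in a functional assay on the whole organism (stomach) with Rattus norvegicus as the target (on this read-out lower numbers stand for an effect already at smaller amounts and higher numbers for an effect only at larger amounts of compound), a limit of the assay and not a number.
Compound 2, `C/N=C(\NC#N)NCCCCn1nc(-c2ccccc2)ccc1=O`, 32.4 mg/kg.

Among the compounds with values here, compound 2 carries the only number in this set; the other value shown is a limit. In this assay compound 1 gives only a limit, (the limit of > 100 mg/kg in this assay, at which 1 of the 2 values shown sits). Compound 1 and compound 2 differ in more than one place, so what their two values show is all that can be said of them.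

Compound 3, `C=CCNC(=S)NCCCCn1nc(-c2ccccc2)ccc1=O`, has not been measured. It differs from compound 2 in one place: a group of 6 heavy atoms (4 carbon, 1 nitrogen, 1 sulfur; no ring) in place of a group of 6 heavy atoms (3 carbon, 3 nitrogen; no ring), on an amine nitrogen.

Within the data shown here, since no step between measured compounds is available, the size of the step from compound 2 to compound 3 in this assay is expected to be modest, in the direction of an effect only at somewhat larger amounts, but it may well stay within the scatter. The expected step is a 1.5-fold higher number from compound 2 to compound 3 (0.19 log units; within the scatter). For compound 3 the expected value is 50 mg/kg, with a range from 18 mg/kg to 150 mg/kg.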

Compound 3, dose for half-maximal effect: > 100 mg/kg
Compound 3 was reported as a limit; the forecaster's own chance of this, stated with the estimate: 30%; middle value at least 2.0-fold (0.30 log units) from the limit.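

In this assay, the change on the amine nitrogen from the cyanoguanidine group to the allyl thiourea group gives an at least 3.0-fold higher number from compound 2 to compound 3 (0.48 log units; beyond the scatter). Within the data shown here, this is the first comparison in the set that differs in one place, and it shows that the read-out responds to the group on this nitrogen while the rest of the molecule stays the same. Compound 1 and compound 3, the two thioureas shown, each give only a limit of the assay and not a number: the limit of > 100 mg/kg in this assay, at which 2 of the 3 values shown sit.

On these data alone, the step from compound 1 to compound 3 cannot be read, so how allyl and naphthalen-1-yl compare on the thiourea remains open. Also open, as far as these compounds go, is whether a urea on this nitrogen would stay close to compound 2 or reach the same limit as the thioureas.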